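A few compounds are considered here, and "the series" means these few. Any claim that something is new, unique, unknown or untested is made for them only; others in the source may bear on it.

Of the compounds shown here, three have been tested in a functional assay on T47D cells (Homo sapiens) for cytotoxicity, read by CCK-8 assay, with a stated time of 4 days; a lower number here means a stronger inhibitor, a higher number a weaker inhibitor. Compound 1 `Oc1ccc(-c2cc(-c3ccc(O)cc3)nc(-c3ccccc3O)c2)cc1` gives 50000 nM, compound 2 `Oc1cccc(-c2cc(-c3ccccc3O)cc(-c3ccccc3O)n2)c1` gives 5760 nM, and compound 3 `Oc1cccc(-c2cc(-c3ccccc3O)cc(-c3cccc(O)c3)n2)c1` gives 4570 nM. Compound 3 thus has the lowest of the three numbers, though compound 2 lies within the scatter of it, while compound 1 sits well apart. For the measured compounds named here, the one measured step that matches the present change is a 1.3-fold lower number from compound 2 to compound 3 (0.10 log units; within the scatter), a shift too small to count. Compound 4 `Oc1cccc(-c2cc(-c3cccc(O)c3)nc(-c3cccc(O)c3)c2)c1` differs from compound 3 by 3-hydroxyphenyl in place of 2-hydroxyphenyl on an aromatic carbon, the same kind of swap made once more. Going by the values given here, with only that small precedent, no step beyond the scatter is expected; the estimated step is a 1.2-fold lower number from compound 3 to compound 4 (0.08 log units; within the scatter), and compound 4 is expected to give about 3800 nM, between 1500 nM and 9500 nM.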

Compound 4, half-maximal inhibitory concentration: 2050 nM
The estimate for compound 4 lay 1.9-fold (0.27 log units) above the measured number; the measured number falls inside the stated range.
By their numbers in this assay, from the lowest: compound 4; then compounds 3 and 2 (each within the scatter of the next); then compound 1.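

In this assay, 3-hydroxyphenyl in place of 2-hydroxyphenyl opposite the ring nitrogen gives a 2.2-fold lower number from compound 3 to compound 4 (0.35 log units; beyond the scatter), a modest step but one beyond the scatter. The same swap at another place on the core gave a 1.3-fold lower number from compound 2 to compound 3 (0.10 log units; within the scatter), which stayed within the scatter, so this swap need not count equally at every place. Nothing measured here explains the difference. Only hydroxyphenyl groups appear at this position in these compounds. Going by these compounds, whether an aminophenyl or a methoxyphenyl group opposite the ring nitrogen would lower the number further remains open.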